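This account rests on a few compounds, and the source may have more. Where it says the series, first, only, none or still open, it means among the compounds named here.

Series notes. Compound 1 `O=C(OCC1CO1)c1ccccc1-c1ccccc1` gives 18% in an assay on membranes from cerebellum for inhibition of Monoglyceride lipase (Rattus norvegicus), tested at 100 uM; on this read-out higher numbers stand for more inhibition at the one concentration tested (going by the name of the read-out) and lower numbers for less inhibition. Compound 2 `O=C(OCC1CCCCO1)c1ccccc1` gives 24% in this assay, a number that sits within the usual scatter of the value of compound 1, so the two cannot be told apart. Compound 3 `O=C(OCC1CCCCO1)c1cccc(-c2ccccc2)c1` differs from compound 2 by phenyl in place of hydrogen on an aromatic carbon. Among the measured compounds shown here, no measured pair shows what such a change does, so the step of a number 6 percentage points higher from compound 2 to compound 3 (within the scatter) is expected to be small and not clearly beyond the scatter. Compound 3 is estimated at 30% in this assay, with a range of 5% to 60%.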

Compound 3, a percentage reported as inhibition, at one concentration (the size of the read-out at that concentration, not a potency): 49%
Compound 3: middle estimate off by 19 percentage points, on the low side; measured number inside the range.
By their numbers in this assay, from the lowest: compounds 1 and 2 (each within the scatter of the next); then compound 3.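

In this assay, among the compounds shown here, phenyl in place of hydrogen on an aromatic carbon, meta to a large group, gives a number 25 percentage points higher from compound 2 to compound 3 (beyond the scatter) and is the only step that clears the scatter. This position therefore accepts an added aromatic ring, and inhibition rises with it. Nothing in hand gives a reason for the rise.

From the compounds shown here alone, whether a smaller group such as methyl at this position would do the same remains open. So does the effect of an amine or a carboxylic acid on the added phenyl.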